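The compounds below may be only part of what the source reports. "The series", "measured", "known", "first", "only" and "open" are said of these compounds alone.

Measured in an ADME assay on WI-38 cells (Homo sapiens) for cytotoxicity, read by MTT assay, with a stated time of 72 h; on this read-out lower numbers stand for stronger inhibition and higher numbers for weaker inhibition:
Compound 1 `C#Cc1ccc(NC(=O)CCc2cccc3c2B(O)OC3)cc1`: > 100000 nM
Compound 2 `O=C(CCc1cccc2c1B(O)OC2)Nc1ccccc1-c1ccccc1`: 77000 nM

In this assay, compound 1 gives > 100000 nM, which is a limit of the assay and not a number. Compound 1 therefore stands here: the limit of > 100000 nM in this assay, at which 1 of the 2 values shown sits. Within the data shown here, compound 2 gives 77000 nM, the only true number so far.

Compound 3 `O=C(CCc1cccc2c1B(O)OC2)Nc1ccc(-c2ccccc2)cc1` has phenyl in place of ethynyl on an aromatic carbon, para to a large group: phenyl in place of ethynyl on an aromatic carbon. Among the measured compounds shown here, no two measured compounds differ in one place, so no measured step sizes this change. The expected change, an at least 1.4-fold lower number from compound 1 to compound 3 (0.15 log units; that floor lies within the scatter), is a modest one toward stronger inhibition, though its size is uncertain. This expectation rests on compound 2, whose 77000 nM shows that a number can be reached in this series. A further limit reading remains possible. For compound 3 the estimated value is 70000 nM, with an expected range from 30000 nM to 100000 nM.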

Compound 3, half-maximal inhibitory concentration: 32000 nM
The estimate for compound 3 lay 2.2-fold (0.34 log units) above the measured number, and the stated range covers the measured number.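

At the aromatic carbon para to a large group, phenyl in place of ethynyl gives in this assay an at least 3.1-fold lower number from compound 1 to compound 3 (0.49 log units; beyond the scatter). Among these compounds, this is the first change that can be sized at all, and it shows that this position is not silent in this read-out, since a change here alone moves the result from a limit to a true number. The true size of the step stays a floor because compound 1 sits at a limit of the assay and not at a number: the limit of > 100000 nM in this assay, at which 1 of the 3 values shown sits.

Going by these compounds, whether other groups on this carbon, such as an amine or a carboxylic acid, would give a lower or a higher number than phenyl stays open. Also open, on these data alone, is how a longer chain between the amide carbonyl and the shared core would shift the reading.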